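A few compounds are considered here, and "the series" means these few. Any claim that something is new, unique, unknown or untested is made for them only; others in the source may bear on it.

Compound 2 `COc1cccc(CNCCCNc2ccnc3cc(Cc4ccccc4)ccc23)c1O` gives 9.47 in a physicochemical assay for acid dissociation. Compound 1 `COc1ccc(F)cc1CNCCCNc1ccnc2cc(Cc3cc(C)cc(C)c3)ccc12` gives 9.47 in this assay, level with compound 2 at the digits given, and together these two are the highest of the three numbers. Compound 3 `COc1ccc(F)cc1CNCCCNc1ccnc2cc(Oc3ccc(C(C)(C)C)cc3)ccc12` gives 9.28 in this assay, the furthest from compound 2, yet still within the scatter of it. Among the measured compounds shown here, the only step between compounds that differ in one place is a number 0.19 log units lower from compound 1 to compound 3 (within the scatter), a move that stays within the scatter.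

Compound 4 `COc1cccc(CNCCCNc2ccnc3cc(Oc4ccccc4)ccc23)c1O` has not been measured in this assay. Against compound 2 the difference is phenoxy in place of benzyl on an aromatic carbon. For the measured compounds named here, the one step that bears on it is the exchange of a benzyl-type group for a phenoxy-type group on an aromatic carbon of the shared core, a number 0.19 log units lower from compound 1 to compound 3 (within the scatter), and that step did not leave the scatter. No step beyond the scatter is therefore expected in this assay for compound 4; the expected step is a number 0.10 log units lower from compound 2 to compound 4 (within the scatter). Compound 4 is estimated at 9.37, with a range from 9.07 to 9.67.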

Compound 4, acid dissociation constant: 9.28
Beside the measured number, compound 4's estimate is 0.09 log units above it; the measured number falls inside the stated range.
By their numbers in this assay, from the lowest: compounds 3, 4, 1 and 2 (each within the scatter of the next).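

In this assay the plain exchange of phenoxy for benzyl on this aromatic carbon gives a number 0.19 log units lower from compound 2 to compound 4 (within the scatter), so this change, with one hydrogen-bond acceptor entering, stays within the scatter even when the aromatic ring carries no further substituents. The earlier comparison, a number 0.19 log units lower from compound 1 to compound 3 (within the scatter), combined the exchange with different ring substituents; the two steps print the same size, and the result now holds for two different sets of groups elsewhere on the shared core. No measurement at hand accounts for the size of either step.

Still open, on these data alone, is whether an amine or a carboxylic acid on this aromatic carbon would leave the number within the scatter in this assay. Also open, as far as these compounds go, is whether a longer chain in place of the present one would do the same.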